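Replacing a Methyl with a Hydroxy on the Aromatic Ring

The source may hold more compounds than are shown below. What is called first, only, known or untested is meant among the compounds shown, and "the series" means these compounds.

Within the data shown here, compound 2 `CCn1nnc(-c2sc(-c3cccc(C)c3)nc2O)n1` gives 369 nM in an assay on HEK293 cells for inhibition of transient receptor potential cation channel subfamily M member 8 (Homo sapiens), read by FLIPR, with stated times of 5 min and 3 min (on this read-out higher numbers stand for weaker inhibition and lower numbers for stronger inhibition), the highest of the two numbers so far; compound 1 `CCn1nnc(-c2sc(-c3cccc(N)c3)nc2O)n1` gives 61 nM. Among the measured compounds shown here, the only measured step, a 6.0-fold higher number from compound 1 to compound 2 (0.78 log units; beyond the scatter), came with a methyl in place of an amino group on an aromatic carbon. Compound 3 `CCn1nnc(-c2sc(-c3cccc(O)c3)nc2O)n1` differs from compound 2 by hydroxy in place of methyl on an aromatic carbon. Because a 6.0-fold higher number from compound 1 to compound 2 (0.78 log units; beyond the scatter) runs from amino to methyl, and hydroxy, like amino, brings a hydrogen-bond donor, a fall in the number is expected for compound 3, of about a 3.1-fold lower number from compound 2 to compound 3 (0.49 log units; beyond the scatter). Compound 3 is therefore estimated at 120 nM, within a range from 40 nM to 400 nM.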

Compound 3, half-maximal inhibitory concentration: 239 nM
Estimate against measurement, compound 3: 2.0-fold (0.30 log units) below, within the range that was stated.
By their numbers in this assay, from the lowest: compound 1; then compounds 3 and 2 (each within the scatter of the next).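

In this assay, hydroxy and methyl cannot be told apart on this aromatic carbon, with a 1.5-fold lower number from compound 2 to compound 3 (0.19 log units; within the scatter) as the step between them. Amino does stand apart from hydroxy, with a 3.9-fold higher number from compound 1 to compound 3 (0.59 log units; beyond the scatter) as the step, so adding a hydrogen-bond donor here does not by itself match the amino compound. Nothing measured here explains this gap. From the compounds shown here alone, it remains open whether the amino result would hold for a methylamino or dimethylamino group at this place. An aminomethyl group or a carboxylic acid there also remains untested in the compounds shown.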